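This account rests on a few compounds, and the source may have more. Where it says the series, first, only, none or still open, it means among the compounds named here.

Compound 1, `COc1cc(Oc2cccc(Nc3ccccc3)c2)cc(OC)c1CNCc1ccc(Br)cc1`, gives 6230 nM in a functional assay on HCT-116 cells (Homo sapiens) for inhibition, read by MTT assay, with a stated time of 72 h; on this read-out lower numbers stand for stronger inhibition and higher numbers for weaker inhibition.
Compound 2, `COc1cc(Oc2cccc(Nc3ccccc3)c2)cc(OC)c1CNCc1ccc(C)cc1`, gives 13800 nM in this assay.
Compound 3, `COc1cc(Oc2cccc(Nc3ccccc3)c2)cc(OC)c1CN[C@H](C)c1ccccc1`, reaches only the assay limit (the limit of > 20000 nM in this assay, at which 1 of the 3 values shown sits), recorded in this assay as > 20000 nM.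

Compound 3 therefore stands at the limit of this assay, with no number of its own. Compound 4, `COc1cc(Oc2cccc(Nc3ccccc3)c2)cc(OC)c1CNCc1ccc(O)cc1`, differs from it by 4-hydroxybenzyl in place of 1-phenylethyl on an amine nitrogen. Among the compounds with values here, two measured steps bear on this change: an at least 3.2-fold higher number from compound 1 to compound 3 (0.50 log units; beyond the scatter) and an at least 1.4-fold higher number from compound 2 to compound 3 (0.16 log units; that floor lies within the scatter), both of which ran toward the limit as 1-phenylethyl entered. Compound 4 undoes that entry with another 4-substituted benzyl, so a step back to a measurable number is expected, about an at least 1.6-fold lower number from compound 3 to compound 4 (0.22 log units; that floor lies within the scatter). Compound 4 is estimated at 12000 nM in this assay, within 5000 nM to 30000 nM.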

Compound 4, half-maximal inhibitory concentration: 3360 nM
For compound 4 the middle estimate is 3.6-fold (0.55 log units) above the measured one, and the stated range ends above it.
By their numbers in this assay, from the lowest: compounds 4 and 1 (each within the scatter of the next); then compound 2. At a limit, above all of these: compound 3.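

Compound 3 stands at a limit and not at a number: the limit of > 20000 nM in this assay, at which 1 of the 4 values shown sits. In this assay, 4-hydroxybenzyl on the amine nitrogen returns a measurable value, with an at least 5.9-fold lower number from compound 3 to compound 4 (0.77 log units; beyond the scatter). Among the substituents on the aromatic carbon, hydroxy separates from methyl, with a 4.1-fold lower number from compound 2 to compound 4 (0.61 log units; beyond the scatter), while a 1.9-fold lower number from compound 1 to compound 4 (0.27 log units; within the scatter) leaves hydroxy and bromo unresolved.

The compounds shown leave open whether a methoxy group or an amine on that aromatic carbon would read like hydroxy. They also leave open whether plain benzyl would part the effect of the 1-phenylethyl branch from that of the ring substituent.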